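Swapping phenyl for trifluoromethyl on two cytotoxicity-tested cores

A few compounds are considered here, and "the series" means these few. Any claim that something is new, unique, unknown or untested is made for them only; others in the source may bear on it.

Compound 1 `CCOC(=O)c1c(-c2cccc(Oc3ccccc3)c2)[nH]c2cc(F)cc(F)c2c1=O` gives > 21500 nM in an ADME assay on HepG2 cells (Homo sapiens) for cytotoxicity, read by luminescence, with a stated time of 72 h (a higher number here means that more compound is needed for the effect, a lower number that less compound is needed), which is a limit of the assay rather than a number.
Compound 2 `CCOC(=O)c1c(-c2cccc(OC(F)(F)F)c2)[nH]c2cc(F)cc(F)c2c1=O` gives > 21500 nM in this assay, again only a limit.
Compound 3 `CCOC(=O)c1c(-c2cccc(Oc3ccccc3)c2)[nH]c2cc(OC)c(F)cc2c1=O` gives > 21500 nM in this assay, also a limit.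

All three measured compounds sit at the same limit (the limit of > 21500 nM in this assay, at which 3 of the 3 values shown sit). From compound 1 to compound 2 the change is trifluoromethyl in place of phenyl on an oxygen on an aromatic ring, and the resulting step that the two limits leave unreadable from compound 1 to compound 2 cannot be read because both values are limits. The cores of compound 1 and compound 3 differ, but that difference is not broken down here. Compound 4 `CCOC(=O)c1c(-c2cccc(OC(F)(F)F)c2)[nH]c2cc(OC)c(F)cc2c1=O` is not yet measured; it stands to compound 3 as compound 2 stands to compound 1, through (trifluoromethyl in place of phenyl on an oxygen on an aromatic ring), the same change at the same place. Going by the values given here, since the first instance of this change left both compounds at the limit (the limit of > 21500 nM in this assay, at which 3 of the 3 values shown sit), compound 4 is expected to remain at the limit as well, with an estimated value of 30000 nM, meaning an expected step that the limit leaves unreadable from compound 3 to compound 4.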

Compound 4, half-maximal effective concentration: > 21500 nM
Compound 4 was reported as a limit; the forecaster's own chance of this, stated with the estimate: 85%; the middle value lies beyond the limit too.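

Compound 3 and compound 4 are both reported only as limits, so no step between them can be read: the limit of > 21500 nM in this assay, at which 4 of the 4 values shown sit.

The compounds shown leave open what concentration each would need in this assay, and whether phenoxy to trifluoromethoxy changes it.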